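The source may hold more compounds than are shown below. What is called first, only, known or untested is meant among the compounds shown, and "the series" means these compounds.

Measured in a functional assay for antagonist activity at transient receptor potential cation channel subfamily V member 1 (Rattus norvegicus), read by FLIPR; on this read-out lower numbers stand for lower potency and higher numbers for higher potency (the scale is a negative logarithm):
Compound 1 `O=C(Nc1ccccc1Br)N[C@@H]1CCN(c2cccc(C(F)(F)F)n2)C1`: 7.2
Compound 2 `Cc1cccc2c1CCN2CCNC(=O)Nc1ccccc1Br`: 7.4
Compound 3 `Cc1cccc(N2CC[C@H](NC(=O)Nc3ccccc3Br)C2)c1`: < 6.8, a limit of the assay rather than a number.

Only two of these results are numbers. Compound 1 and compound 2 lie within the usual scatter of each other in this assay, so neither can be ranked above the other. Compound 3 gave (the limit of < 6.8 in this assay, at which 1 of the 3 values shown sits).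

The untested compound 4 `O=C(Nc1ccccc1Br)N[C@@H]1CCN(c2ccccn2)C1` differs from compound 1 in one place: hydrogen in place of trifluoromethyl on an aromatic carbon. Among the measured compounds shown here, no measured pair shows this change on its own, so its size must be guessed. Compound 3 also lacks a trifluoromethyl group and gave only a limit, though it differs elsewhere too. Compound 4 is expected to lose some potency, a step of a number 0.50 log units lower from compound 1 to compound 4 (beyond the scatter) in this assay. The estimate for compound 4 is 6.7, from 6 to 7.4.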

Compound 4, negative logarithm of the antagonist equilibrium constant: < 6.6
Compound 4 was reported as a limit; the forecaster's own chance of this, stated with the estimate: 35%; middle value at least 0.10 log units from the limit.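

Replacing trifluoromethyl with hydrogen on this aromatic carbon, next to the ring nitrogen, lowers potency in this assay, a step of a number at least 0.60 log units lower from compound 1 to compound 4 (beyond the scatter). Compound 4 gave a limit of the assay, not a number: the limit of < 6.6 in this assay, at which 1 of the 4 values shown sits. This is the only comparison shown that changes a single place, and it shows that potency in compound 1 depends on what occupies this carbon.

The compounds shown leave open whether a smaller replacement, such as a nitrile or a methoxy group, would hold the potency of compound 1. They also leave open whether the trifluoromethyl group would matter as much on a different core.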